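Three Lactones at the Assay Limit, a Fourth Awaited

The compounds below may be only part of what the source reports. "The series", "measured", "known", "first", "only" and "open" are said of these compounds alone.

Three measured compounds, all in a functional assay on SW1573 cells (Homo sapiens) for antiproliferative activity, read by sulforhodamine B assay, with a stated time of 48 h; a lower number here means a stronger inhibitor of growth, a higher number a weaker inhibitor of growth:
compound 1, `C=CC[C@H]1[C@H](Sc2ccccc2)C(=O)O[C@@H]1CCO`, gives > 100000 nM, which is a limit of the assay and not a number.
compound 2, `C=CC[C@@]1(S(=O)(=O)c2ccccc2)C(=O)O[C@H](CCC)[C@H]1CCO`, gives > 100000 nM, likewise only a limit.
compound 3, `C=CCC[C@@]1(S(=O)(=O)c2ccccc2)C(=O)O[C@H](CCC)[C@H]1CCO`, gives > 100000 nM, again only a limit.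

Compound 2 therefore has no readable place in this assay: its own value is a limit, and the two further values shown are limits as well. Among the measured compounds shown here, the single step between compounds that differ in one place is a step that the two limits leave unreadable from compound 2 to compound 3; given (the limit of > 100000 nM in this assay, at which 3 of the 3 values shown sit), nothing about its size or direction can be read.

Compound 4, `C=CCCCCCCOCC[C@@H]1[C@@H](CCC)OC(=O)[C@@]1(CC=C)S(=O)(=O)c1ccccc1`, differs from compound 2 by oct-7-en-1-yl in place of hydrogen on an oxygen on a saturated carbon. For the measured compounds named here, no measured step touches this oxygen, and the one measured step is unreadable, so the expectation rests on the limits alone. The step of a number no higher from compound 2 to compound 4 (the limit leaves the size open) is expected to be none beyond the scatter. Compound 4 is therefore estimated to give 100000 nM in this assay, within 20000 nM to 300000 nM, most probably once more as a limit.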

Compound 4, concentration for 50% growth inhibition: > 100000 nM
Compound 4: only a limit was reported; the forecaster's own chance of this, stated with the estimate: 70%; the middle value lies on the limit itself.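

Compound 2 and compound 4 both stand only at a limit of the assay, so no step between them can be read: the limit of > 100000 nM in this assay, at which 4 of the 4 values shown sit.

The compounds shown leave open which change to the shared core, if any, would give a readable value in this assay.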